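A few compounds are considered here, and "the series" means these few. Any claim that something is new, unique, unknown or untested is made for them only; others in the source may bear on it.

Measured in a functional assay on B16 cells (Mus musculus) for inhibition; a lower number here means a stronger inhibitor, a higher number a weaker inhibitor:
- compound 1 `COc1cc2oc(=O)cc(COC(=O)/C=C/c3ccccc3)c2cc1OC`: > 10 ug/mL (a limit)
- compound 2 `COc1cc2oc(=O)cc(COC(=O)/C=C/c3ccc(Cl)cc3)c2cc1OC`: > 10 ug/mL (a limit)
- compound 3 `COc1ccc(/C=C/C(=O)OCc2cc(=O)oc3cc(OC)c(OC)cc23)cc1O`: 3 ug/mL

For the measured compounds named here, compound 3 gives 3 ug/mL, the only true number in the set. Beyond it there is only (the limit of > 10 ug/mL in this assay, at which 2 of the 3 values shown sit).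

The next entry is compound 4 `COc1cc2oc(=O)cc(COC(=O)/C=C/c3ccc(N)cc3)c2cc1OC`, not yet measured. The change is 4-aminophenyl in place of 3-hydroxy-4-methoxyphenyl on a double-bonded chain carbon bound to a double-bonded chain carbon. In words, 4-aminophenyl comes in place of 3-hydroxy-4-methoxyphenyl, on a double-bonded chain carbon bound to a double-bonded chain carbon.

Going by the values given here, two measured steps bear on this: an at least 3.3-fold lower number from compound 1 to compound 3 (0.52 log units; beyond the scatter) and an at least 3.3-fold lower number from compound 2 to compound 3 (0.52 log units; beyond the scatter). Both came with the arrival of the 3-hydroxy-4-methoxyphenyl group that now leaves, and both are beyond the scatter, though their true size is open. The remaining step, a step that the two limits leave unreadable from compound 1 to compound 2, gives no size. Among the compounds with values here, no measured compound carries 4-aminophenyl, so its own contribution is unknown.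

The expectation is therefore that the number in this assay rises and that part or all of the gain is lost. The expected change is a 2.3-fold higher number from compound 3 to compound 4 (0.37 log units; beyond the scatter). A result reported only as a limit would fit this expectation.

For compound 4 the estimated value is 7 ug/mL, with an expected range from 2 ug/mL to 20 ug/mL.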

Compound 4, half-maximal inhibitory concentration: > 10 ug/mL
Compound 4: no number, only a limit; the forecaster's own chance of this, stated with the estimate: 45%; middle value at least 1.4-fold (0.15 log units) from the limit.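

In this assay, the series now shows an at least 3.3-fold higher number from compound 3 to compound 4 (0.52 log units; beyond the scatter), so 4-aminophenyl on the double-bonded chain carbon does not keep what 3-hydroxy-4-methoxyphenyl gave, although both groups are counted with one hydrogen-bond donor. For the compounds shown here, compound 3 remains the only compound with a true number, and a single hydrogen-bond donor on the aromatic ring, as counted for 4-aminophenyl, is not enough on its own to bring a compound of this set to a readable value. The steps among compound 1, compound 2 and compound 4 cannot be read, as all three stand at one limit of the assay: the limit of > 10 ug/mL in this assay, at which 3 of the 4 values shown sit.

As far as these compounds go, how far compound 4 lies past that limit stays open, so amino, chloro and hydrogen cannot be ranked against one another. Also open, from the compounds shown here alone, is which part of 3-hydroxy-4-methoxyphenyl carries the gain: a 3-hydroxyphenyl or a 4-methoxyphenyl group in the same place would separate the contribution of the hydroxy group from that of the methoxy group in this assay.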